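Compound 3 to compound 4: changing the aryl group

The source may hold more compounds than are shown below. What is called first, only, known or untested is meant among the compounds shown, and "the series" means these compounds.

Results in a functional assay on A549 cells (Homo sapiens) for antiproliferative activity, read by MTT assay, with a stated time of 72 h (on this read-out higher numbers stand for weaker inhibition and lower numbers for stronger inhibition), for the measured compounds
- compound 1 `COc1cc2ncnc(Nc3ccc(C#N)cc3F)c2cc1OCCCN1CCNCCNCCNCC1` gives > 50000 nM as a limit of the assay
- compound 2 `COc1cc2ncnc(Nc3ccc(F)c(Br)c3)c2cc1OCCCN1CCNCCNCC1` gives 34300 nM as a measured number
- compound 3 `COc1cc2ncnc(Nc3ccc(Cl)c(C(F)(F)F)c3)c2cc1OCCCN1CCNCCNCC1` gives 6230 nM as a measured number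

Only two of these results are true numbers, and compound 3 holds the lower of them. Compound 4 `COc1cc2ncnc(Nc3ccc(C#N)cc3F)c2cc1OCCCN1CCNCCNCC1` has not yet been measured. It differs from compound 3 in one place 4-cyano-2-fluorophenyl in place of 4-chloro-3-(trifluoromethyl)phenyl on a nitrogen on an aromatic ring where 4-cyano-2-fluorophenyl replaces 4-chloro-3-(trifluoromethyl)phenyl on a nitrogen on an aromatic ring.

One measured step changes the group at this same place, a 5.5-fold lower number from compound 2 to compound 3 (0.74 log units; beyond the scatter) and it shows that this assay can respond to such a swap. Compound 3 carries the group that gave the lower number in that step, so losing it is expected to raise the number by a similar or somewhat larger amount. Compound 1 carries the same 4-cyano-2-fluorophenyl but differs elsewhere, and its > 50000 nM result is only a limit, so it offers a weak hint in the same direction.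

The estimated change is a 4.5-fold higher number from compound 3 to compound 4 (0.65 log units; beyond the scatter) and would mean weaker inhibition. For compound 4 the estimate is 28000 nM with an expected range from 10000 nM to 50000 nM in this assay.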

Compound 4, half-maximal inhibitory concentration: > 50000 nM
Compound 4 was reported as a limit; the forecaster's own chance of this, stated with the estimate: 25%; middle value at least 1.7-fold (0.25 log units) from the limit.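

In this assay compound 4 gives > 50000 nM, which is a limit of the assay and not a true number. Placing 4-cyano-2-fluorophenyl in place of 4-chloro-3-(trifluoromethyl)phenyl on the nitrogen gives an at least 8.0-fold higher number from compound 3 to compound 4 (0.90 log units; beyond the scatter), so the earlier response to a swap at this position now extends to a clear loss of inhibition, and the real size of the step may be larger. Set against the 3-bromo-4-fluorophenyl group, the result is less firm, with an at least 1.4-fold higher number from compound 2 to compound 4 (0.16 log units; that floor lies within the scatter), so these two groups cannot be told apart on this floor, and the step between the two limits cannot be read at all.

On these data alone, how much weaker compound 4 really is stays open, since the read-out stops at a ceiling: the limit of > 50000 nM in this assay, at which 2 of the 4 values shown sit. As far as these compounds go, it is also open whether the nitrile or the fluorine goes with the loss, a question that a plain 4-cyanophenyl group or a 4-chloro-2-fluorophenyl group at the same nitrogen would help to separate.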